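The compounds below may be only part of what the source reports. "The series", "measured", "known", "first", "only" and "open" are said of these compounds alone.

Among the three compounds measured so far, compound 3 `Cc1ccc(/C(=C/CCCCC(=O)O)c2cccnc2)cc1` gives the highest number: in an assay (Equus caballus) for inhibition of Thromboxane-A synthase (Homo sapiens), using microsomes (on this read-out lower numbers stand for stronger inhibition and higher numbers for weaker inhibition), compound 3 gives 85 nM, while compound 2 `C/C(=C/CCCCC(=O)O)c1cccnc1` gives 71 nM and compound 1 `Cc1ccsc1/C(=C/CCCCC(=O)O)c1cccnc1` gives 29 nM. The step from compound 2 to compound 3 lies within the scatter a 1.2-fold higher number from compound 2 to compound 3 (0.08 log units; within the scatter), but the step from compound 1 to compound 3 is larger a 2.9-fold higher number from compound 1 to compound 3 (0.47 log units; beyond the scatter). Compound 4 `O=C(O)CCCC/C=C(\c1cccnc1)c1ccccc1Br` differs from compound 3 in one place: 2-bromophenyl in place of 4-methylphenyl on a double-bonded chain carbon bound to an aromatic carbon and a double-bonded chain carbon. The measured steps at this place, a 2.4-fold higher number from compound 1 to compound 2 (0.39 log units; beyond the scatter) and a 2.9-fold higher number from compound 1 to compound 3 (0.47 log units; beyond the scatter), were modest, and none exchanged one phenyl for another, so only a small shift is expected, if any, in this assay: a 1.5-fold lower number from compound 3 to compound 4 (0.19 log units; within the scatter). For compound 4 the estimate in this assay is 55 nM, with a range from 15 nM to 180 nM.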

Compound 4, half-maximal inhibitory concentration: 130 nM
Beside the measured number, compound 4's estimate is 2.4-fold (0.37 log units) below it; low and high end bracket the measured number.
By their numbers in this assay, from the lowest: compound 1; then compounds 2, 3 and 4 (each within the scatter of the next).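

In this assay, 2-bromophenyl in place of 4-methylphenyl gives a 1.5-fold higher number from compound 3 to compound 4 (0.18 log units; within the scatter) and, in place of methyl, a 1.8-fold higher number from compound 2 to compound 4 (0.26 log units; within the scatter) at this position, so compounds 2, 3 and 4 stay together despite quite different groups on this carbon. Against 3-methylthiophen-2-yl, 2-bromophenyl gives a 4.5-fold higher number from compound 1 to compound 4 (0.65 log units; beyond the scatter) and this is the largest step here, leaving compound 1 alone at the low end. Nothing available explains this pattern. Still open, as far as these compounds go, is whether plain thiophen-2-yl, without its methyl, would match compound 1, and whether an amine on the phenyl ring would shift the number.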